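Nitrile for Methoxy on a Biaryl Urea Series

The compounds below may be only part of what the source reports. "The series", "measured", "known", "first", "only" and "open" are said of these compounds alone.

Compound 1, `COc1ccc(-c2ccc(CN(CC(=O)C(C)(C)O)C(=O)NC3CCN(Cc4ccc(C)cc4)CC3)cc2)cc1`, and compound 2, `Cc1ccc(CN2CCC(NC(=O)N(CC(=O)C(C)(C)O)Cc3ccc(-c4cccc(C#N)c4)cc3)CC2)cc1`, share one core and differ only by 3-cyanophenyl in place of 4-methoxyphenyl on an aromatic carbon. In an in vitro functional assay on HEK293 cells for antagonist activity at melanin-concentrating hormone receptor 1 (Homo sapiens), read by GTPgammaS binding, with a stated time of 45 min (on this read-out lower numbers stand for lower potency and higher numbers for higher potency (the scale is a negative logarithm)), compound 1 gives < 5, which is a limit of the assay and not a number, as noted in the limit of < 5 in this assay, at which 1 of the 3 values shown sits. In this assay compound 2 gives 5.3. The change is therefore a number at least 0.30 log units higher from compound 1 to compound 2 (that floor lies within the scatter); how much more than that floor is not known.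

Compound 3, `COc1ccc(-c2ccc(CN(CCC3CCN(Cc4ccc(C)cc4)CC3)C(=O)NC(C)C)cc2)cc1`, carries a second core; the difference between the two cores is not broken down here. In this assay, for the measured compounds named here, compound 3 gives 6.34, the higher of the two numbers measured so far.

Compound 4, `Cc1ccc(CN2CCC(CCN(Cc3ccc(-c4cccc(C#N)c4)cc3)C(=O)NC(C)C)CC2)cc1`, arises from compound 3 by 3-cyanophenyl in place of 4-methoxyphenyl on an aromatic carbon. Because the same change and the same place are shown for compound 1 and compound 2 with a number at least 0.30 log units higher from compound 1 to compound 2 (that floor lies within the scatter), the step from compound 3 to compound 4 is expected to be a number 0.36 log units higher from compound 3 to compound 4 (beyond the scatter), resting on only that one earlier pair. Compound 4 is accordingly expected to give 6.7, with a likely range of 6.2 to 7.3.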

Compound 4, negative logarithm of the antagonist equilibrium constant: 6
Estimate against measurement, compound 4: 0.70 log units above; measured number outside the range, below it.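

On the core of compound 3, 3-cyanophenyl in place of 4-methoxyphenyl gives a number 0.34 log units lower from compound 3 to compound 4 (beyond the scatter) in this assay. Set beside the earlier pair, this shows that the change does not carry over with the same effect from one core to the other: the same change on two cores in this assay, a number at least 0.30 log units higher (that floor lies within the scatter) from compound 1 to compound 2 and a number 0.34 log units lower (beyond the scatter) from compound 3 to compound 4, at least 0.64 log units apart, beyond the scatter of two such steps

With only one pair on each core, this does not show why the two cores differ or how the change would behave on a further core, and compound 1 stands at a limit of the assay rather than at a number, so the full size of the earlier step stays unknown: the limit of < 5 in this assay, at which 1 of the 4 values shown sits.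

Still open, as far as these compounds go, is whether a plain phenyl ring, or a phenyl ring carrying a fluorine or an amide in place of the nitrile, would give the same gap between the two cores. Also open is which part of the difference between the two cores accounts for that gap.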